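From compound 1 to compound 4 in a cytotoxicity assay

The source may hold more compounds than are shown below. What is called first, only, known or untested is meant among the compounds shown, and "the series" means these compounds.

Compound 1 `Cc1nc(-c2cccc(NC(=O)C3CCCN(C(=O)c4cc(C(F)(F)F)cc(C(F)(F)F)c4)C3)c2)cs1` was tested in an ADME assay on PC-3 cells (Homo sapiens) for cytotoxicity, read by WST assay, tested at 100 uM (on this read-out lower numbers stand for less inhibition and higher numbers for more inhibition at the one concentration tested (going by the name of the read-out)), where compound 1 gives 1%. Compound 2 `O=C(Nc1cccc(Cc2ccccc2)c1)C1CCCN(C(=O)c2cccc(-c3ccco3)c2)C1` gives 0% in this assay, and compound 3 `COC(=O)c1cccc(C(=O)N2CCCC(C(=O)Nc3ccc(Cl)cc3)C2)c1` gives 0%. Compound 1 thus stands apart from neither of them: compound 2 and compound 3 both lie within the scatter of it, so the three numbers cannot be told from one another. Compound 4 `COC(=O)c1cc(-c2cccc(NC(=O)C3CCCN(C(=O)c4cc(C(F)(F)F)cc(C(F)(F)F)c4)C3)c2)co1` has not yet been measured. It differs from compound 1 by 5-(methoxycarbonyl)furan-3-yl in place of 2-methyl-1,3-thiazol-4-yl on an aromatic carbon. Among the measured compounds shown here, no step between measured compounds is available to guide the expectation, and all three measured numbers sit at the floor of the read-out. In this assay the expected step is a number 2 percentage points higher from compound 1 to compound 4 (within the scatter), none beyond the scatter. For compound 4 the estimated value in this assay is 3%, with a range from -8% to 15%.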

Compound 4, a percentage reported as inhibition, at one concentration (the size of the read-out at that concentration, not a potency): 0%
Compound 4: the middle estimate sits 3 percentage points above what was measured; measured number inside the range.
By their numbers in this assay, from the lowest: compounds 2, 3, 4 and 1 (each within the scatter of the next).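

In this assay, among the compounds shown here, putting 5-(methoxycarbonyl)furan-3-yl in place of 2-methyl-1,3-thiazol-4-yl on the aromatic carbon gives a number 1 percentage points lower from compound 1 to compound 4 (within the scatter) and is the first step that can be read at this position. The two groups cannot be told apart here: across the swap of one five-membered aromatic ring for another, with a methoxycarbonyl group added, the number in this assay is level, at the floor of the read-out. Nothing measured here bears on the reason for this.

On these data alone, whether an amine or a carboxylic acid at this position would lift the number beyond the scatter remains open.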